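Swapping chloro for fluoro on a fused-ring growth inhibitor

This account rests on a few compounds, and the source may have more. Where it says the series, first, only, none or still open, it means among the compounds named here.

Of the compounds shown here, three sharing one core have been measured in a functional assay on PC-3 cells (Homo sapiens) for inhibition, read by sulforhodamine B assay, with a stated time of 48 h, tested at 100 uM; a lower number here means less inhibition of growth, a higher number more inhibition of growth at the concentration tested. Compound 1 `Cc1ccc2occ(C3N=C(c4ccccc4)SS3)c(=O)c2c1` gives 40%. Compound 2 `O=c1c(C2N=C(c3ccccc3)SS2)coc2ccc(Cl)cc12` gives 62%, and compound 3 `O=c1c(C2N=C(c3ccccc3)SS2)coc2cc(Cl)c(Cl)cc12` gives 70%. Compound 2 therefore stands second highest of the three numbers: its nearest neighbour is compound 3, and that gap lies within the scatter, while its furthest neighbour is compound 1, a gap beyond the scatter.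

The step to compound 4 `O=c1c(C2N=C(c3ccccc3)SS2)coc2ccc(F)cc12` is fluoro in place of chloro on an aromatic carbon, so one halogen is exchanged for another on the same aromatic carbon. Going by the values given here, no measured step swaps one halogen for another, so the bearing steps are indirect. The step of a number 22 percentage points higher from compound 1 to compound 2 (beyond the scatter) shows that placing chloro at that position instead of methyl raised inhibition by a modest amount, and the step of a number 8 percentage points higher from compound 2 to compound 3 (within the scatter) shows that a second chloro added only a change within the scatter. Fluoro keeps a halogen at the position, so in this assay a small drop, or none beyond the scatter, is expected from compound 2 to compound 4.

Compound 4 is therefore estimated at 50%, within a range of 35% to 65%, a step of a number 12 percentage points lower from compound 2 to compound 4 (beyond the scatter) that is expected rather than measured.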

Compound 4, percent growth inhibition at one concentration: 32%
For compound 4 the middle estimate is 18 percentage points above the measured one; measured number outside the range, below it.
By their numbers in this assay, from the lowest: compounds 4 and 1 (each within the scatter of the next); then compounds 2 and 3 (each within the scatter of the next).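

In this assay, going by these compounds alone, the choice of halogen at this aromatic carbon clearly matters: there is a number 30 percentage points lower from compound 2 to compound 4 (beyond the scatter) and so chloro and fluoro cannot be treated as interchangeable here, something the earlier compounds could not show because none of them exchanged one halogen for another. Fluoro also does not stand apart from methyl at this carbon, with a number 8 percentage points lower from compound 1 to compound 4 (within the scatter) and the earlier rise of a number 22 percentage points higher from compound 1 to compound 2 (beyond the scatter) therefore belongs to chloro among these compounds, not to halogens as a group. Nothing available here explains why chloro and fluoro differ so much at this position.

What the compounds shown leave open is how other groups on this carbon, such as bromo, methoxy or an amine, would compare with chloro and with fluoro. Also open, as far as these compounds go, is whether the gap between chloro and fluoro would persist with the second chloro of compound 3 in place, or whether a fluoro at that second carbon would behave as it does here.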